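Compound 2 and Its Methoxycarbonyl Counterpart

The compounds below may be only part of what the source reports. "The series", "measured", "known", "first", "only" and "open" are said of these compounds alone.

Among the compounds with values here, compound 2 `Nc1nc(N)c(CCCN(Cc2ccc(NC(CCC(=O)O)C(=O)O)cc2)c2cc(F)c([N+](=O)[O-])cc2[N+](=O)[O-])c(O)n1` gives 44000 nM in a functional assay on CCRF-CEM cells (Homo sapiens) for cytotoxicity, in the absence of a further agent (on this read-out higher numbers stand for weaker inhibition and lower numbers for stronger inhibition), and is the only compound measured so far that has a number. Compound 1 `COC(=O)c1ccc(CN(CCCc2c(N)nc(N)nc2O)c2cc(F)cc(F)c2[N+](=O)[O-])cc1` gives > 100000 nM in this assay as a limit of the assay and not a number. Compound 3 `Nc1nc(N)c(CCCNc2cc(F)ccc2[N+](=O)[O-])c(O)n1` reads > 100000 nM in this assay as a limit too.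

The next compound to be measured is compound 4 `COC(=O)c1ccc(CN(CCCc2c(N)nc(N)nc2O)c2cc(F)c([N+](=O)[O-])cc2[N+](=O)[O-])cc1`, which is compound 2 with one change. That change, (methoxycarbonyl in place of (1,3-dicarboxypropyl)amino on an aromatic carbon), puts methoxycarbonyl in place of (1,3-dicarboxypropyl)amino on an aromatic carbon. Within the data shown here, no measured pair shows this change alone, so the expectation is loose. No step beyond the scatter is expected in this assay, and the estimated 1.1-fold higher number from compound 2 to compound 4 (0.06 log units; within the scatter) is small. Compound 1 also carries methoxycarbonyl and stands at > 100000 nM as a limit, so a reading at that limit would not surprise. In this assay the estimated value for compound 4 is 50000 nM within an expected range of 12000 nM to 100000 nM for now.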

Compound 4, half-maximal inhibitory concentration: 3900 nM
The estimate for compound 4 lay 13-fold (1.11 log units) above the measured number; the whole stated range lies above it.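

In this assay, methoxycarbonyl in place of (1,3-dicarboxypropyl)amino gives an 11-fold lower number from compound 2 to compound 4 (1.05 log units; beyond the scatter). This shows that the substituent on this aromatic carbon, para to a large group, matters for the read-out, and that here the group with 4 heavy atoms and 0 hydrogen-bond donors goes with the lower number, not the group with 10 heavy atoms and 3 hydrogen-bond donors. Compound 4 also gives a true number, clear of the ceiling that holds other compounds in the set: the limit of > 100000 nM in this assay, at which 2 of the 4 values shown sit.

A single pair cannot tell whether the step comes from gaining the ester or from losing the diacid side chain. A lone carboxylic acid or a simple amine on the same carbon would separate these two readings, and the compounds shown leave that question open.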